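The compounds below may be only part of what the source reports. "The series", "measured", "known", "first", "only" and "open" are said of these compounds alone.

Measured in an ADME assay on HepG2 2.2.15 cells (Homo sapiens) for cytotoxicity; a lower number here means that less compound is tolerated, a higher number that more compound is tolerated:
Compound 1 `O=C(Nc1ncc(C(Oc2ccc3cc(Br)ccc3c2)c2ccc(Cl)cc2)s1)c1ccccc1`: "not toxic" (no number reported)
Compound 2 `COc1ccc(C(=O)Nc2ncc(C(Oc3ccc4cc(Br)ccc4c3)c3ccc(Cl)cc3)s2)cc1`: > 50000 nM

Compound 2 gives only a limit of the assay in this assay, not a number. Compound 1 likewise carries no number. The reference point for the series is therefore (the limit of > 50000 nM in this assay, at which 1 of the 2 values shown sits). Compound 3 `O=C(Nc1ncc(C(Oc2ccc3cc(Br)ccc3c2)c2ccc(Cl)cc2)s1)c1ccc(F)cc1` is not yet measured; its change from compound 2 is fluoro in place of methoxy on an aromatic carbon. For the measured compounds named here, no step between measured compounds exists, so no size can be read from the data. For compound 3 a value near the limit is expected, with a step that the limit leaves unreadable from compound 2 to compound 3 meaning nothing beyond the scatter. Compound 3 is estimated at 60000 nM, between 25000 nM and 150000 nM, most likely again reported only as a limit.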

Compound 3, half-maximal cytotoxic concentration: "not toxic" (no number reported)
For compound 3 the study gives words and no number; there is nothing to compare the estimate with.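

No step can be read between compound 2 and compound 3, since compound 2 sits at an assay limit and compound 3 carries only the words "not toxic". What the compounds shown leave open is how far any of them lies from a toxic concentration in this assay.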